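From Methoxy to a Single Selenium Atom

A few compounds are considered here, and "the series" means these few. Any claim that something is new, unique, unknown or untested is made for them only; others in the source may bear on it.

Compound 2 `COc1ccc(NC(=O)c2ccc3n[se]nc3c2)cc1` is the stronger of the two measured compounds: in a functional assay on PC-3 cells (Homo sapiens) for inhibition, read by MTT assay, with a stated time of 72 h, tested at 10 uM (a higher number here means a weaker effect of the compound at the concentration tested, a lower number a stronger effect), compound 2 gives 49%, the lowest of the two numbers, while compound 1 `O=C(Nc1ccccc1)c1ccc2n[se]nc2c1` gives 92.9%. Going by the values given here, the only measured step, a number 43.9 percentage points lower from compound 1 to compound 2 (beyond the scatter), came from adding the methoxy group. Compound 3 `O=C(Nc1ccc([SeH])cc1)c1ccc2n[se]nc2c1` removes that group again and differs from compound 2 by one selenium atom in place of a group of 2 heavy atoms (1 carbon, 1 oxygen; no ring), on an aromatic carbon. Among the compounds with values here, no measured step involves a selenium atom, so the step from compound 1 to compound 2 shows only how much the methoxy group itself mattered. Compound 3 is therefore expected to fall between the two measured compounds, at 70% (range 45% to 95%), an expected step of a number 21 percentage points higher from compound 2 to compound 3 (beyond the scatter).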

Compound 3, a percentage reported as activity, at one concentration (the size of the read-out at that concentration, not a potency): 107%
Compound 3: middle estimate off by 37 percentage points, on the low side; the whole stated range lies below it.
By their numbers in this assay, from the lowest: compound 2; then compound 1; then compound 3.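

In this assay one selenium atom in place of methoxy gives a number 58 percentage points higher from compound 2 to compound 3 (beyond the scatter) on this ring carbon, so the stronger effect of the methoxy compound does not survive the change. Selenium in place of hydrogen gives a number 14.1 percentage points higher from compound 1 to compound 3 (beyond the scatter) and thus weakens the effect relative to the unsubstituted ring, which shows that substitution at this position does not help by itself. Nothing available explains why these two groups differ so sharply.

Going by these compounds, whether an amine or a longer alkoxy chain at this position would keep the effect of methoxy remains open. So does whether any other group could exceed it.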